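Carbamate to urea on the piperazine carbonyl

The source may report more compounds than this note shows. Statements on the series, on what has been measured and on what is new or still open speak of the compounds shown alone.

Two compounds of the series have numbers in an assay on Sf9 cells for inhibition of activin receptor type-1 (Homo sapiens), read by HTRF, with a stated time of 3 h, in the presence of a further agent that is not named here; on this read-out higher numbers stand for weaker inhibition and lower numbers for stronger inhibition. Compound 1 `COC(=O)N1C[C@@H](C)N(c2ncc3[nH]nc(-c4ccc(N5CCN(C)CC5)cc4)c3n2)[C@@H](C)C1` gives 0.98 nM in this assay. Compound 2 `COC(=O)N1C[C@@H](C)N(c2ncc3[nH]nc(-c4ccc(N5CCN[C@H](C)C5)nc4)c3n2)[C@@H](C)C1` gives 0.85 nM in this assay; the two numbers sit within the usual scatter of one another, so neither is set apart from the other.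

Compound 3 `C[C@@H]1CN(c2ccc(-c3n[nH]c4cnc(N5[C@H](C)CN(C(=O)N(C)C)C[C@@H]5C)nc34)cn2)CCN1` differs from compound 2 in one place: dimethylamino in place of methoxy on a carbonyl carbon. Cut one bond further out, the change reads methoxycarbonyl to dimethylcarbamoyl. Among the compounds with values here, no pair of measured compounds shows this change, so there is no measured step to lean on; what is known is only that compound 1 and compound 2 give close numbers.

The expectation for compound 3 is no step beyond the scatter from compound 2, with a 1.3-fold higher number from compound 2 to compound 3 (0.11 log units; within the scatter) as the estimated change. Compound 3 is expected to give 1.1 nM in this assay, within a range from 0.4 nM to 3 nM.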

Compound 3, half-maximal inhibitory concentration: 6.4 nM
Beside the measured number, compound 3's estimate is 5.8-fold (0.76 log units) below it; the whole stated range lies below it.
By their numbers in this assay, from the lowest: compounds 2 and 1 (each within the scatter of the next); then compound 3.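

In this assay, within the data shown here, dimethylamino in place of methoxy on a carbonyl carbon gives a 7.5-fold higher number from compound 2 to compound 3 (0.88 log units; beyond the scatter), the first measured change at this place. Compound 1 and compound 2 both carry methoxycarbonyl, so their close numbers said nothing about this group, whereas this step shows that the number responds to the exchange of methoxy for dimethylamino alone, with the carbonyl and its amide-type nitrogen in a ring kept. Nothing on hand explains why the number moves with this exchange.

With a single replacement shown, the step cannot be assigned to nitrogen in place of oxygen or to the second carbon; methylamino or ethoxy on the same carbonyl would separate the two. Going by these compounds, whether the step carries over to the core of compound 1 also remains open.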